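Moving the chlorine on the styryl arm of compound 2

A few compounds are considered here, and "the series" means these few. Any claim that something is new, unique, unknown or untested is made for them only; others in the source may bear on it.

Compound 2 `NS(=O)(=O)c1cc(-c2nnc(/C=C/c3cccc(Cl)c3)o2)c(Cl)cc1SCc1ccccc1` has the lowest number of the two measured here in a functional assay on HCT-116 cells (Homo sapiens) for cytotoxicity, read by MTT assay, with a stated time of 72 h; a lower number here means a stronger inhibitor, a higher number a weaker inhibitor: compound 2 gives 12000 nM. Within the data shown here, its only measured neighbour, compound 1 `NS(=O)(=O)c1cc(-c2nnc(Cn3cc(-c4ccccc4)nn3)o2)c(Cl)cc1SCc1ccccc1`, gives 75000 nM in this assay, and the single known step is a 6.3-fold lower number from compound 1 to compound 2 (0.80 log units; beyond the scatter). Compound 3 `NS(=O)(=O)c1cc(-c2nnc(/C=C/c3ccc(Cl)cc3)o2)c(Cl)cc1SCc1ccccc1` is the next question. It keeps every atom of compound 2 but joins them differently: 4-chlorophenyl in place of 3-chlorophenyl on a double-bonded chain carbon bound to a double-bonded chain carbon. Among the measured compounds shown here, no measured step bears on this change, since the only step known concerns a different group entirely, so there is no basis for predicting a shift in either direction beyond the scatter in this assay. The expected step is therefore no change at the digits printed from compound 2 to compound 3 (within the scatter), essentially a standstill. Compound 3 is estimated at 12000 nM, with a plausible range from 4000 nM to 36000 nM.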

Compound 3, half-maximal inhibitory concentration: 12000 nM
The estimate for compound 3 equals the measured number at the digits printed; low and high end bracket the measured number.
By their numbers in this assay, from the lowest: compounds 2 and 3 (each within the scatter of the next); then compound 1.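

In this assay, 4-chlorophenyl in place of 3-chlorophenyl on the double-bonded chain gives no change at the digits printed from compound 2 to compound 3 (within the scatter), so these two chlorine placements cannot be told apart in this assay. The advantage over the (4-phenyl-1H-1,2,3-triazol-1-yl)methyl arm also holds with the chlorine in its new place, as 2-(4-chlorophenyl)ethenyl gives a 6.3-fold lower number from compound 1 to compound 3 (0.80 log units; beyond the scatter); within these compounds, that advantage does not depend on which of the two placements is present. No measured evidence is available to explain why the swap leaves the number unchanged.

The compounds shown leave open whether the chlorine is needed at all, which a plain phenyl ring could test, or whether a methoxy group or a nitrile in its place would shift the number. They also leave open what a saturated ethyl link would do in place of the double-bonded chain.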